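Methylenelactone series: methoxy step on the aryl ring

The compounds below may be only part of what the source reports. "The series", "measured", "known", "first", "only" and "open" are said of these compounds alone.

Compound 1 `C=C1C(=O)O[C@@H](c2ccccc2)[C@H]1C` gives 14% in a functional assay on MIA PaCa-2 cells (Homo sapiens) for cytotoxicity, read by MTT assay, with a stated time of 72 h, tested at 10 uM; on this read-out higher numbers stand for a weaker effect at the one concentration tested and lower numbers for a stronger effect.
Compound 2 `C=C1C(=O)O[C@@H](c2ccc(OC)cc2)[C@H]1C` gives 9% in this assay.
Compound 3 `C=C1C(=O)O[C@H](c2ccccc2)[C@H]1c1ccccc1` gives 1% in this assay.

From compound 1 to compound 2 the change is methoxy in place of hydrogen on an aromatic carbon, and the step it made is a number 5 percentage points lower from compound 1 to compound 2 (within the scatter). Compound 4 `C=C1C(=O)O[C@H](c2ccc(OC)cc2)[C@H]1c1ccccc1` is not yet measured; it carries the change methoxy in place of hydrogen on an aromatic carbon on compound 3. The difference between the core of compound 1 and the core of compound 3 is not broken down here. The two places are not worded alike: in compound 1 the methoxy sits para to a group of 8 heavy atoms, in compound 3 para to a large group, so this is the same kind of change, not the same change. Compound 3 already gives 1% in this assay, a read-out that cannot fall much further. For compound 4 a step of a number 1 percentage points higher from compound 3 to compound 4 (within the scatter) is expected, resting on a number 5 percentage points lower from compound 1 to compound 2 (within the scatter). Compound 4 is estimated at 2%, between 0% and 12%.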

Compound 4, a percentage reported as activity, at one concentration (the size of the read-out at that concentration, not a potency): 0%
Beside the measured number, compound 4's estimate is 2 percentage points above it; measured number inside the range.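

Methoxy in place of hydrogen on an aromatic carbon of the core of compound 3 gives a number 1 percentage points lower from compound 3 to compound 4 (within the scatter) in this assay. Set beside the earlier step, the change reads alike on the two cores: the same change on two cores in this assay, a number 5 percentage points lower (within the scatter) from compound 1 to compound 2 and a number 1 percentage points lower (within the scatter) from compound 3 to compound 4, 4 percentage points apart, within the scatter of two such steps This shows no core dependence that can be detected, but neither step stands beyond the scatter and the read-out of compound 3 leaves little room to fall, so it does not show that methoxy has a real effect on either core, or that the two cores would respond alike where more room existed.

Still open, going by these compounds, is whether an amine, a carboxylic acid or a longer chain such as ethoxy, para to a large group, would shift the read-out beyond the scatter. Also open, on these data alone, is how either core responds at concentrations other than the one tested.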